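Trimming a Hydroxyethyl to Methyl on a Long-Chain Amino Alcohol

The compounds below may be only part of what the source reports. "The series", "measured", "known", "first", "only" and "open" are said of these compounds alone.

The compounds here are long saturated chains carrying an amine and hydroxyl groups. Compound 1 is `CCCCCCCCCCCCCCC[C@@H](O)[C@@H](N)[C@@H](C)O` and compound 2 is `CCCCCCCCC[C@@H](O)[C@@H](N)[C@@H](C)CC`. Among the compounds with values here, in a functional assay on SW1573 cells (Homo sapiens) for antiproliferative activity, read by sulforhodamine B assay, with a stated time of 48 h (a lower number here means a stronger inhibitor of growth, a higher number a weaker inhibitor of growth), compound 1 gives 17000 nM, the highest of the two numbers measured so far; compound 2 gives 13000 nM, and the gap between them is within the scatter, so the pair shows no real difference. Compound 3, `CCCCCCCCCCCCCCC[C@@H](O)[C@H](C)N`, is not yet measured. It differs from compound 1 in one place: methyl in place of 1-hydroxyethyl on a saturated chain carbon bound to an amine nitrogen and a saturated chain carbon. Within the data shown here, no step between measured compounds touches this kind of change, so there is no direct guide; the two measured compounds, which differ in more than one place, simply give numbers within the scatter of each other. The step of a 1.3-fold higher number from compound 1 to compound 3 (0.11 log units; within the scatter) is therefore expected to be small, at most a modest weakening, not clearly beyond the scatter. Compound 3 is estimated at 22000 nM, with a range from 8000 nM to 60000 nM.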

Compound 3, concentration for 50% growth inhibition: 1300 nM
Compound 3: the middle estimate sits 17-fold (1.23 log units) above what was measured, outside the stated range (below it).
By their numbers in this assay, from the lowest: compound 3; then compounds 2 and 1 (each within the scatter of the next).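

Replacing 1-hydroxyethyl with methyl on a saturated chain carbon bound to an amine nitrogen and a saturated chain carbon gives, in this assay, a 13-fold lower number from compound 1 to compound 3 (1.12 log units; beyond the scatter), so this place strongly affects growth inhibition, which the two earlier compounds could not show. The change removes a hydrogen-bond donor, a hydrogen-bond acceptor and a defined stereocentre together, and this single step cannot separate their contributions. Nothing measured here explains why the smaller group gives the stronger inhibitor.

The compounds shown leave open whether a plain hydrogen or an ethyl group in the same place would match methyl, which would help show how much of the step depends on the size of the group. They also leave open whether a methoxymethyl group, which keeps an oxygen but has no hydroxyl, would behave more like compound 1 or compound 3.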